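The compounds below may be only part of what the source reports. "The series", "measured", "known", "first", "only" and "open" are said of these compounds alone.

Working notes on the series in an ADME assay on HEK293 cells (Homo sapiens) for cytotoxicity, with a stated time of 6 h; on this read-out higher numbers stand for lower toxicity in this test and lower numbers for higher toxicity in this test:

- compound 1 `CCCC(C)Nc1nc(N)nc2ccccc12` gives the limit > 25000 nM
- compound 2 `CCCCNc1nc(N)nc2c(F)cccc12` gives the limit > 18000 nM
- compound 3 `CCCCNc1nc(N)nc2cccc(C)c12` gives the limit > 25000 nM

Compound 3 stands only at a limit, > 25000 nM in this assay, and has no measured number. Compound 1 and compound 2 also give only limits, so no order among the three can be read from these results.

Compound 4 `CCCCNc1nc(N)nc2cccc(OCc3cccnc3)c12` is the next compound to follow from compound 3. The structural change is (pyridin-3-yl)methoxy in place of methyl on an aromatic carbon and amounts to (pyridin-3-yl)methoxy in place of methyl on an aromatic carbon, ortho to a fused ring. For the measured compounds named here, no measured step between compounds that differ in one place is available to size this change.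

With all three compounds reaching only limits, no step beyond the scatter is expected in either direction. The expected change is a number no higher from compound 3 to compound 4 (the limit leaves the size open) and is estimated to stay within the usual scatter. For compound 4 the estimate is 25000 nM with an expected range from 12000 nM to 50000 nM in this test, and a limit rather than a number is the likeliest report.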

Compound 4, half-maximal cytotoxic concentration: > 25000 nM
Compound 4 was reported as a limit (the forecaster's own chance of this, stated with the estimate: 70%); the middle value lies on the limit itself.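

In this assay compound 4 gives > 25000 nM, which is a limit and not a number. Compound 3 also stands only at a limit, and no step can be read from compound 3 to compound 4. The compounds shown leave open how the half-maximal cytotoxic concentration changes with (pyridin-3-yl)methoxy in place of methyl.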